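A few compounds are considered here, and "the series" means these few. Any claim that something is new, unique, unknown or untested is made for them only; others in the source may bear on it.

In an assay on HEK293 cells for negative allosteric modulation of metabotropic glutamate receptor 5 (Homo sapiens), read by FLIPR (on this read-out higher numbers stand for weaker inhibition and lower numbers for stronger inhibition), compound 1 `Cc1cccc(S(=O)(=O)N2CC(c3nc(-c4cccc(Cl)c4)no3)C2)c1` gives 390 nM. Among the compounds with values here, compound 2 `Cc1ccc(S(=O)(=O)N2CC(c3nc(-c4cccc(Cl)c4)no3)C2)cc1` is its analogue with 4-methylphenyl in place of 3-methylphenyl on the sulfonyl sulfur; in this assay compound 2 gives 920 nM, the higher of the two numbers measured so far, and the step of a 2.4-fold higher number from compound 1 to compound 2 (0.37 log units; beyond the scatter) is modest but beyond the scatter. Compound 3 `Cc1ccc(S(=O)(=O)N2CC(c3nc(-c4cccc(C)c4)no3)C2)cc1` differs from compound 2 at the other end of the shared core: methyl in place of chloro on an aromatic carbon, that is, 3-chlorophenyl to 3-methylphenyl. Within the data shown here, no measured step touches this position; the only step known, from compound 1 to compound 2, concerns the sulfonyl aryl and says nothing about exchanging chloro for methyl. Since chloro and methyl are both single heavy atoms without donors or acceptors, the expected change is small, though a slight weakening seems more likely than a gain, so the step of a 1.6-fold higher number from compound 2 to compound 3 (0.21 log units; within the scatter) is estimated. Compound 3 is therefore expected to give about 1500 nM in this assay, within 500 nM to 4500 nM.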

Compound 3, half-maximal inhibitory concentration: 670 nM
Beside the measured number, compound 3's estimate is 2.2-fold (0.35 log units) above it, and the stated range covers the measured number.
By their numbers in this assay, from the lowest: compounds 1, 3 and 2 (each within the scatter of the next, the first and the last beyond it).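

In this assay the exchange of 3-chlorophenyl for 3-methylphenyl, with the 4-methylphenyl on the sulfonyl sulfur kept, gives a 1.4-fold lower number from compound 2 to compound 3 (0.14 log units; within the scatter), so this read-out does not tell the two groups apart at this position. Within the data shown here, this is the first reading at this end of the shared core, and it shows that chloro can give way to methyl here without a step beyond the scatter. Nothing at hand bears on why the two groups read alike.

The compounds shown leave open whether a methoxy group, an amine or a longer chain such as propyl on this aromatic carbon would also read alike. They also leave open whether the same exchange reads the same with the 3-methylphenyl on the sulfonyl sulfur of compound 1.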